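The source may hold more compounds than are shown below. What is called first, only, known or untested is meant among the compounds shown, and "the series" means these compounds.

Compound 2 `CC(=O)c1ccc(-c2ccc(OCc3cc(C(=O)O)oc3C)cc2)cc1` gives the lowest number of the three compounds measured in an assay on cells for displacement of a labelled ligand from prostaglandin E2 receptor EP4 subtype (Homo sapiens), read by scintillation counting (on this read-out higher numbers stand for weaker inhibition and lower numbers for stronger inhibition), at 150 nM. Compound 1 `Cc1oc(C(=O)O)cc1COc1ccc(-c2ccc(Cl)cc2)cc1` gives 1000 nM, and compound 3 `Cc1oc(C(=O)O)cc1COc1ccc(-c2ccc(C#N)cc2)cc1` gives 1500 nM. The measured steps were a 6.7-fold lower number from compound 1 to compound 2 (0.82 log units; beyond the scatter), a 10-fold higher number from compound 2 to compound 3 (1.00 log units; beyond the scatter) and a 1.5-fold higher number from compound 1 to compound 3 (0.18 log units; within the scatter). Compound 4 `CC(=O)c1ccc(-c2ccc(OCc3cc(C(=O)NS(=O)(=O)c4ccccc4)oc3C)cc2)cc1` differs from compound 2 by (phenylsulfonyl)amino in place of hydroxy on a carbonyl carbon. For the measured compounds named here, none of the measured steps touches the carbonyl carbon; each exchanges only the group on the aromatic carbon, so no measured step bears directly on this change. With the core of compound 2 kept intact, the expected step is a 1.9-fold lower number from compound 2 to compound 4 (0.27 log units; within the scatter), a shift that may not exceed the scatter. Compound 4 is therefore estimated at 80 nM, with a range from 20 nM to 400 nM.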

Compound 4, inhibition constant: 20 nM
Compound 4: the middle estimate sits 4.0-fold (0.60 log units) above what was measured; the range from low to high includes it.
By their numbers in this assay, from the lowest: compound 4; then compound 2; then compounds 1 and 3 (each within the scatter of the next).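

In this assay, for the compounds shown here, (phenylsulfonyl)amino in place of hydroxy on the carbonyl carbon gives a 7.5-fold lower number from compound 2 to compound 4 (0.88 log units; beyond the scatter), so this position, which the earlier steps left untouched, also moves the number beyond the scatter. The carbonyl carbon therefore need not carry hydroxy for the number to stay low, and the larger group is accepted here. Nothing given here accounts for this step. From the compounds shown here alone, it remains open whether the same exchange holds with chloro or cyano in place of acetyl, and whether (methylsulfonyl)amino or a plain amino group on that carbonyl carbon would do the same.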